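Fluoro for Hydrogen on the Benzamide of Compound 3

The compounds below may be only part of what the source reports. "The series", "measured", "known", "first", "only" and "open" are said of these compounds alone.

Compound 3 `NC(=O)c1c(NC(=O)c2ccccc2)sc2c1CCN(C(=S)Nc1ccccc1Cl)C2` was tested in a functional assay on MKN-74 cells (Homo sapiens) for antiproliferative activity, with a stated time of 24 h (a higher number here means a weaker inhibitor, a lower number a stronger inhibitor), where compound 3 gives 11800 nM. Two relatives share the same fused core: compound 1 `NC(=O)c1c(NC(=O)c2ccccc2F)sc2c1CCN(Cc1c(Cl)cccc1Cl)C2`, which gives 7430 nM, and compound 2 `NC(=O)c1c(NC(=O)c2ccccc2F)sc2c1CCN(Cc1ccc(Cl)cc1Cl)C2`, which gives 9610 nM. The gaps from compound 3 to both lie within the usual scatter, so the three cannot be told apart on these numbers. Among the compounds with values here, the only step between measured compounds, a 1.3-fold higher number from compound 1 to compound 2 (0.11 log units; within the scatter), concerns the dichlorophenyl group on the amine nitrogen in the ring, not the benzamido part, and lies within the scatter as well.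

Compound 4 `NC(=O)c1c(NC(=O)c2ccccc2F)sc2c1CCN(C(=S)Nc1ccccc1Cl)C2` has not yet been measured. It differs from compound 3 by fluoro in place of hydrogen on an aromatic carbon. Within the data shown here, no measured pair isolates this change: compound 1 and compound 2 carry the fluoro group but also a different substituent on the amine nitrogen in the ring, so their numbers give no direct comparison. The account therefore expects a step of a 1.2-fold lower number from compound 3 to compound 4 (0.07 log units; within the scatter), nothing beyond the scatter. In this assay compound 4 is expected to give 10000 nM, in the range 4000 nM to 25000 nM.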

Compound 4, half-maximal inhibitory concentration: 11100 nM
For compound 4 the middle estimate is 1.1-fold (0.05 log units) below the measured one; low and high end bracket the measured number.
By their numbers in this assay, from the lowest: compounds 1, 2, 4 and 3 (each within the scatter of the next).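

In this assay, within the data shown here, the step of a 1.1-fold lower number from compound 3 to compound 4 (0.03 log units; within the scatter) is the first measured pair to isolate fluoro in place of hydrogen on this aromatic carbon, ortho to a large group, and the two compounds cannot be told apart. With the 2-fluorophenyl group held fixed, changing the group on the amine nitrogen in the ring gives a 1.2-fold higher number from compound 2 to compound 4 (0.06 log units; within the scatter) and a 1.5-fold higher number from compound 1 to compound 4 (0.17 log units; within the scatter), so no difference can be read from that exchange either. No evidence on hand bears on this result.

The compounds shown leave open whether a different group at this place, such as methoxy, an amine or a carboxylic acid, would move the number beyond the scatter. They also leave open whether any change to the shared core would do so.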